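Amide to Methyl-oxazole: One Step from a Limit

A few compounds are considered here, and "the series" means these few. Any claim that something is new, unique, unknown or untested is made for them only; others in the source may bear on it.

Compound 1 `CCOC(=O)CN(c1ccccc1)[C@@H]1c2cc(C#N)ccc2OC(C)(C)[C@H]1O` in a functional assay (aorta) with Rattus norvegicus as the target (a lower number here means a stronger inhibitor, a higher number a weaker inhibitor), gives > 30000 nM, which is a limit rather than a number.
Compound 2 `CCOC(=O)CN(c1nc2ccccc2o1)[C@H]1c2cc(C#N)ccc2OC(C)(C)[C@@H]1O` in this assay gives > 30000 nM, again a limit.
Compound 3 `CCNC(=O)CN(c1ccccc1)[C@H]1c2cc(C#N)ccc2OC(C)(C)[C@@H]1O` in this assay gives > 30000 nM, also a limit.

Compound 3 therefore stands where every measured compound here stands: at the edge of what this assay can report, as the limit of > 30000 nM in this assay, at which 3 of the 3 values shown sit, records. None of the three gives a number that could be ranked against another, so nothing can be said about which of them is stronger or weaker.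

Compound 4 `Cc1cc(CN(c2ccccc2)[C@H]2c3cc(C#N)ccc3OC(C)(C)[C@@H]2O)on1` differs from compound 3 in a single place: 3-methyl-1,2-oxazol-5-yl in place of ethylcarbamoyl on a saturated chain carbon bound to a nitrogen on an aromatic ring. No pair of measured compounds shows what such a change does in this assay, so the size and direction of the step cannot be read from anything shown. Because compound 3 sits at > 30000 nM, a limit, even a real gain would have to be large before this assay returned a number at all.

On that basis, compound 4 is expected to move by about an at least 1.2-fold lower number from compound 3 to compound 4 (0.07 log units; that floor lies within the scatter), giving an estimated value of 25000 nM, within a range from 4000 nM to 150000 nM, with a good chance that only a limit is reported again.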

Compound 4, half-maximal inhibitory concentration: > 30000 nM
Compound 4 gave a limit, no number; the forecaster's own chance of this, stated with the estimate: 60%; middle value at least 1.2-fold (0.07 log units) from the limit.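

In this assay compound 4 gives > 30000 nM, which is a limit and not a number. Compound 3 also gives only a limit, so the step from one to the other cannot be read in size or direction. The compounds shown leave open whether any change to the shared core would return an actual number, since all of them sit at one value: the limit of > 30000 nM in this assay, at which 4 of the 4 values shown sit.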